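Three Enones at the Cytotoxicity Limit, and a Fourth

This account rests on a few compounds, and the source may have more. Where it says the series, first, only, none or still open, it means among the compounds named here.

Compound 1 `O=C(/C=C/c1ccc2c(c1)B(O)OC2)c1ccc(Cl)c(Cl)c1`: in an ADME assay on L929 cells (Mus musculus) for cytotoxicity, read by resazurin assay, with a stated time of 72 h (a lower number here means a stronger inhibitor, a higher number a weaker inhibitor), compound 1 reaches only the assay limit > 10 ug/mL.
Compound 2 `O=C(/C=C/c1ccc2c(c1)B(O)OC2)c1ccc(C(F)(F)F)cc1`: in this assay compound 2 reaches only the assay limit > 10 ug/mL.
Compound 3 `O=C(O)c1ccc(C(=O)/C=C/c2ccc3c(c2)B(O)OC3)cc1`: in this assay compound 3 reaches only the assay limit > 10 ug/mL.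

Each of these values is a limit, not a number. Compound 3 therefore stands exactly where its two companions stand, at the edge of what this assay can report, and the limit of > 10 ug/mL in this assay, at which 3 of the 3 values shown sit, gathers all three. For the measured compounds named here, the only single change among the measured compounds, a step that the two limits leave unreadable from compound 2 to compound 3, cannot be sized, since both ends are limits.

Compound 4 `O=C(/C=C/c1ccc2c(c1)B(O)OC2)c1ccc(I)cc1` differs from compound 3 by iodo in place of carboxy on an aromatic carbon. Going by the values given here, no measured step bears readably on this change; compound 1 and compound 2 show only that they too sit at the limit. The expected outcome for compound 4 in this assay is 15 ug/mL, within 5 ug/mL to 50 ug/mL. This estimate means a step that the limit leaves unreadable from compound 3 to compound 4, expected to stay unreadable, most likely reported as another limit.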

Compound 4, half-maximal inhibitory concentration: > 10 ug/mL
Compound 4 ended at the assay's limit; the forecaster's own chance of this, stated with the estimate: 60%; the middle value is on the limit's open side.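

Compound 4 gives no readable step against compound 2 or compound 3: each comparison has a limit at both ends, not a number. The four compounds leave open where each true value lies in this assay and whether changing the group on the aromatic ring alters it at all.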